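Swapping the benzyl halogens on a diamino core

The compounds below may be only part of what the source reports. "The series", "measured", "known", "first", "only" and "open" are said of these compounds alone.

Measured compounds:
- compound 1 `Nc1cc(N)c2nc(-c3ccccc3)c(NCc3ccc(Cl)c(Cl)c3)nc2c1`: 46800 nM
- compound 2 `CCOC(=O)[C@H](CCC(=O)O)NC(=O)c1ccc(Sc2nc3cc(N)cc(N)c3nc2-c2ccccc2)cc1`: 43700 nM
- compound 3 `CCOC(=O)[C@H](CCC(=O)O)NC(=O)c1ccc(Oc2nc3cc(N)cc(N)c3nc2-c2ccccc2)cc1`: 25100 nM

Of the compounds shown here, three sharing the same core have been measured in a functional assay on NCI-H226 cells (Homo sapiens) for inhibition, read by sulforhodamine B assay, with a stated time of 48 h; a lower number here means a stronger inhibitor of growth, a higher number a weaker inhibitor of growth. Compound 1 gives 46800 nM, the highest of the three numbers, yet its gaps to compound 2 and to compound 3 both fall within the usual scatter of this assay, so no ordering among them can be claimed.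

Compound 4 `Nc1cc(N)c2nc(-c3ccccc3)c(NCc3ccc(F)cc3)nc2c1` has not yet been measured. Going by the values given here, its one difference from compound 1 is 4-fluorophenyl in place of 3,4-dichlorophenyl on a saturated chain carbon bound to a nitrogen on an aromatic ring. Among the compounds with values here, no step between two measured compounds isolates this kind of change, so there is nothing in the data to say which way it should go. The three measured values all sit close together despite very different groups on the core, which suggests the change may leave the number roughly where compound 1 stands.

For compound 4 the expected value is 50000 nM, with a range from 20000 nM to 125000 nM. The step from compound 1 to compound 4 is thus expected to be a 1.1-fold higher number from compound 1 to compound 4 (0.03 log units; within the scatter), a move that would stay within the scatter.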

Compound 4, concentration for total growth inhibition: 47900 nM
Estimate against measurement, compound 4: 1.0-fold (0.02 log units) above; the measured number falls inside the stated range.
By their numbers in this assay, from the lowest: compounds 3, 2, 1 and 4 (each within the scatter of the next).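

In this assay, the change at the saturated chain carbon bound to a nitrogen on an aromatic ring is a 1.0-fold higher number from compound 1 to compound 4 (0.01 log units; within the scatter). Going by these compounds alone, compound 1 and compound 4 therefore cannot be told apart, which gives the first direct reading at this position: here, 4-fluorophenyl in place of 3,4-dichlorophenyl makes no measurable difference. No supporting evidence bears on why this is so.

Within the data shown here, this single step covers only two halogen-bearing phenyl groups, so it remains open whether the position would stay as insensitive to a phenyl carrying a carboxylic acid or an amine. A longer chain between the nitrogen and the phenyl ring, or an unsubstituted benzyl group, also remains untested among the compounds shown.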